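Shortening the Urea Substituent of Compound 1

A few compounds are considered here, and "the series" means these few. Any claim that something is new, unique, unknown or untested is made for them only; others in the source may bear on it.

In a functional assay on L1210 cells (Mus musculus) for inhibition, read by MTT assay (a lower number here means a stronger inhibitor, a higher number a weaker inhibitor), compound 1 `CCCCNC(=O)N1CC1C#N` gives 12000 nM, the lowest of the three numbers recorded. Compound 3 `N#CC1CN1C(=O)NC1CCCCC1` gives 16000 nM, which lies within the scatter of compound 1, so the two cannot be ordered. Compound 2 `N#CC1CN1C(=O)Nc1ccc(Cl)cc1Cl` gives 33000 nM, a gap to compound 1 that stands beyond the scatter. Compound 4 `CCNC(=O)N1CC1C#N` has not been measured; it differs from compound 1 by hydrogen in place of ethyl on a saturated chain carbon, two bonds along the chain from an amide-type nitrogen. Going by the values given here, no step between measured compounds of this kind exists, so the account can only lean on the spread of the three numbers, which is narrow. For compound 4 in this assay the step of a 1.3-fold higher number from compound 1 to compound 4 (0.10 log units; within the scatter) is expected to be small and not clearly beyond the scatter. Compound 4 is therefore estimated at 15000 nM, with a range from 6000 nM to 40000 nM.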

Compound 4, half-maximal inhibitory concentration: 14000 nM
For compound 4 the middle estimate is 1.1-fold (0.03 log units) above the measured one; the range from low to high includes it.
By their numbers in this assay, from the lowest: compounds 1, 4 and 3 (each within the scatter of the next); then compound 2.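

Hydrogen in place of ethyl on a saturated chain carbon, two bonds along the chain from an amide-type nitrogen, gives a 1.2-fold higher number from compound 1 to compound 4 (0.07 log units; within the scatter) in this assay, the first single-place step read at this position. Butyl to ethyl therefore leaves two chain carbons gone with no difference that can be told from the scatter, so the two compounds cannot be ordered. Nothing measured on hand accounts for this result.

On these data alone, whether a chain longer than butyl would behave the same stays open. So does the effect of an amine or a carboxylic acid at the end of the chain.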